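Working notes: one more methoxy in the series

This account rests on a few compounds, and the source may have more. Where it says the series, first, only, none or still open, it means among the compounds named here.

Compound 1 `COc1ccc(C[C@H]2C(=O)OC[C@@H]2Cc2ccccc2)cc1`: 67000 nM
Compound 2 `COc1ccc(C[C@H]2C(=O)OC[C@@H]2Cc2ccccc2)cc1OC`: > 100000 nM

In a functional assay on HL-60 cells (Homo sapiens) for cytotoxicity, read by WST assay, with a stated time of 48 h (on this read-out lower numbers stand for an effect already at smaller amounts and higher numbers for an effect only at larger amounts of compound), compound 1 gives 67000 nM as a number. In this assay compound 2 gives > 100000 nM, which is a limit of the assay and not a number. Compound 2 therefore stands only at the limit of > 100000 nM in this assay, at which 1 of the 2 values shown sits.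

Compound 3 `COc1cc(C[C@H]2C(=O)OC[C@@H]2Cc2ccccc2)cc(OC)c1OC` carries methoxy in place of hydrogen on an aromatic carbon, ortho to a methoxy group, meta to a large group and meta to a methoxy group (methoxy in place of hydrogen on an aromatic carbon). Among the compounds with values here, the one measured step of the same kind is an at least 1.4-fold higher number from compound 1 to compound 2 (0.17 log units; that floor lies within the scatter). It gives a floor and no firm size. Within the data shown here, with that step as the only guide, no step beyond the scatter is expected in this assay, and any shift would be expected towards higher numbers. For compound 3 the estimate is 100000 nM, with an expected range of 45000 nM to 220000 nM. The estimate amounts to a number no higher from compound 2 to compound 3 (the limit leaves the size open).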

Compound 3, half-maximal effective concentration: > 100000 nM
Compound 3: a limit, no number; the forecaster's own chance of this, stated with the estimate: 65%; the middle value sits exactly at the limit.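

In this assay compound 3 gives > 100000 nM, a limit of the assay and not a number. Within the data shown here, compound 2 also stands at a limit, and no step from compound 2 to compound 3 can be read. The compounds shown leave open where the true values of compound 2 and compound 3 lie, and whether the added methoxy shifts the number at all.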